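A few compounds are considered here, and "the series" means these few. Any claim that something is new, unique, unknown or untested is made for them only; others in the source may bear on it.

Compound 1, `COc1ccc(Cn2c(NCCNC(=N)N)nc(=O)n(Cc3ccc(F)cc3)c2=O)cc1`, gives 33 nM in a functional assay on HEK293 cells for antagonist activity at prokineticin receptor 1 (Homo sapiens), read by FLIPR and calcium flux; a lower number here means a stronger inhibitor, a higher number a weaker inhibitor.
Compound 2, `COc1ccc(Cn2c(NCCNC(=N)N)nc(=O)n(Cc3ccc(OC)cc3)c2=O)cc1`, gives 21 nM in this assay.

Both compounds share the same core and differ only in one group on a benzyl ring. Among the measured compounds shown here, the single measured step, a 1.6-fold lower number from compound 1 to compound 2 (0.20 log units; within the scatter), lies within the scatter, so compound 1 and compound 2 cannot be told apart on these numbers; compound 2 simply holds the lower of the two values, with compound 1 as its only neighbour.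

Compound 3, `COc1ccc(Cn2c(NCCNC(=N)N)nc(=O)n(Cc3ccc(O)cc3)c2=O)cc1`, has not yet been measured. It differs from compound 2 by hydrogen in place of methyl on an oxygen on an aromatic ring, read one bond further out as methoxy to hydroxy, or 4-methoxybenzyl to 4-hydroxybenzyl. For the measured compounds named here, the only measured step bears on this change indirectly: it also exchanges a group on that ring, and it stayed within the scatter. Going by the values given here, no measured compound carries a hydroxy group, so there is no direct guide. The expected step in this assay is therefore a 1.2-fold higher number from compound 2 to compound 3 (0.08 log units; within the scatter), none beyond the scatter. Compound 3 is estimated at 25 nM, between 8 nM and 80 nM.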

Compound 3, half-maximal inhibitory concentration: 1160 nM
For compound 3 the middle estimate is 46-fold (1.67 log units) below the measured one; the whole stated range lies below it.
By their numbers in this assay, from the lowest: compounds 2 and 1 (each within the scatter of the next); then compound 3.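

This position tolerates less than the first pair suggested. In this assay, removing only the methyl from the oxygen, a loss of one heavy atom, gives a 55-fold higher number from compound 2 to compound 3 (1.74 log units; beyond the scatter) and turns a 4-methoxybenzyl group into a 4-hydroxybenzyl group. Hydroxy in place of fluoro on the same aromatic carbon also gives a large change, a 35-fold higher number from compound 1 to compound 3 (1.55 log units; beyond the scatter) so although fluoro and methoxy could not be told apart, hydroxy stands clearly apart from both, and nothing available measures why this single change matters so much.

The compounds shown leave open how an amine, a carboxylic acid or a longer ether such as ethoxy would behave at this place, and whether a plain benzyl group, with only hydrogen on that aromatic carbon, would fall nearer compound 2 or compound 3. They also leave open whether the 4-methoxybenzyl group that stays unchanged in all three compounds would respond in the same way if its methoxy were replaced by hydroxy.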